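Benzyl in Place of Cyclohexyl: A Second Test

A few compounds are considered here, and "the series" means these few. Any claim that something is new, unique, unknown or untested is made for them only; others in the source may bear on it.

Measured compounds:
compound 1, `O=Cc1ccc(-c2cn3ccnc3c(-c3ccc4ncn(C5CCCCC5)c4c3)n2)cc1`: 25.3%
compound 2, `O=Cc1ccc(-c2cn3ccnc3c(-c3ccc4ncn(Cc5ccccc5)c4c3)n2)cc1`: 25.3%
compound 3, `c1cn2cc(-c3ccc4c(c3)ncn4C3CCCCC3)nc(-c3ccc4ncn(C5CCCCC5)c4c3)c2n1`: 28.5%

Of the compounds shown here, three have been measured in a functional assay on NCI-H522 cells (Homo sapiens) for inhibition, read by sulforhodamine B assay, with a stated time of 48 h, tested at 10 uM; a lower number here means less inhibition, a higher number more inhibition at the concentration tested (going by the name of the read-out). Compound 1 `O=Cc1ccc(-c2cn3ccnc3c(-c3ccc4ncn(C5CCCCC5)c4c3)n2)cc1` gives 25.3%, and compound 2 `O=Cc1ccc(-c2cn3ccnc3c(-c3ccc4ncn(Cc5ccccc5)c4c3)n2)cc1` gives 25.3%. The change between them is benzyl in place of cyclohexyl on an aromatic nitrogen, and the step of no change at the digits printed from compound 1 to compound 2 (within the scatter) shows that this change left the read-out where it was. Compound 3 `c1cn2cc(-c3ccc4c(c3)ncn4C3CCCCC3)nc(-c3ccc4ncn(C5CCCCC5)c4c3)c2n1` gives 28.5% in this assay; its number sits within the scatter of those of compound 1 and compound 2, so no order among the three can be drawn. How the core of compound 3 differs from that of compound 1 is not broken down here.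

Compound 4 `c1ccc(Cn2cnc3ccc(-c4nc(-c5ccc6c(c5)ncn6C5CCCCC5)cn5ccnc45)cc32)cc1` has not yet been measured. It differs from compound 3 by benzyl in place of cyclohexyl on an aromatic nitrogen, the same kind of change as that from compound 1 to compound 2, made at a place described in the same words. For the measured compounds named here, the only measured step of this kind, no change at the digits printed from compound 1 to compound 2 (within the scatter), was flat, so the step of a number 0.5 percentage points lower from compound 3 to compound 4 (within the scatter) is expected to be flat as well, resting on that single earlier step and on the value of compound 3 28.5%. Going by the values given here, compound 4 is therefore estimated to give 28% in this assay, with a range from 16% to 40% to allow for the usual scatter and for the fact that only one earlier example of the change is available.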

Compound 4, a percentage reported as inhibition, at one concentration (the size of the read-out at that concentration, not a potency): -35.2%
Beside the measured number, compound 4's estimate is 63.2 percentage points above it; measured number outside the range, below it.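

In this assay, benzyl in place of cyclohexyl on an aromatic nitrogen gave a number 63.7 percentage points lower from compound 3 to compound 4 (beyond the scatter), whereas the same change had left the read-out flat on the core of compound 1. Set side by side, the two steps show that the change did not carry over from one core to the other: the same change on two cores in this assay, no change at the digits printed (within the scatter) from compound 1 to compound 2 and a number 63.7 percentage points lower (beyond the scatter) from compound 3 to compound 4, 63.7 percentage points apart, beyond the scatter of two such steps. For the compounds shown here, this shows that, in these two pairs, the outcome of exchanging cyclohexyl for benzyl depended on the core that carried it, so the flat step could not be transferred; it does not show which feature of the two cores is responsible, and with only two pairs it gives no general rule for the series.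

The compounds shown leave open whether a further core would follow the flat step or the large one, and whether the result on the core of compound 3 belongs to benzyl in particular or would also appear with a different group on that nitrogen, such as a longer chain or a chain ending in an amine or a carboxylic acid. They also leave open how these steps would look at other concentrations or in other cells, since all four numbers come from one single-concentration read-out on one cell line.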